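From Methyl to Chloro at One Aromatic Carbon

A few compounds are considered here, and "the series" means these few. Any claim that something is new, unique, unknown or untested is made for them only; others in the source may bear on it.

This small set begins with compound 1 (`Cc1ccc(S(=O)(=O)NC(C2=CC(=O)c3c(O)ccc(O)c3C2=O)C(C)C)cc1`) and compound 2 (`Cc1ccc(S(=O)(=O)NC(C)C2=CC(=O)c3c(O)ccc(O)c3C2=O)cc1`), which differ in the group carried on the carbon attached to the shared core. In a functional assay on HL-60 cells (Homo sapiens) for cytotoxicity, read by MTT assay (a lower number here means a stronger inhibitor, a higher number a weaker inhibitor), compound 1 has the entry "not determined" (no result reported), so it offers no number for comparison. In this assay compound 2 gives 30 nM. Among the compounds with values here, that is the only number available, so compound 2 cannot yet be ranked and serves as the single point of reference.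

Compound 3 (`CC(NS(=O)(=O)c1ccc(Cl)cc1)C1=CC(=O)c2c(O)ccc(O)c2C1=O`) is the next to be measured and keeps compound 2 intact apart from one group. It has chloro in place of methyl on an aromatic carbon, para to a large group, which turns 4-methylphenyl into 4-chlorophenyl (chloro in place of methyl on an aromatic carbon). Within the data shown here, no measured pair shows how activity responds to a change at this place. The expectation therefore starts from compound 2 at 30 nM, with no shift beyond the usual scatter anticipated in this assay in either direction. The estimated step is no change at the digits printed from compound 2 to compound 3 (within the scatter). For compound 3 the expected value is 30 nM, with an estimated range of 10 nM to 90 nM.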

Compound 3, half-maximal inhibitory concentration: 250 nM
Estimate against measurement, compound 3: 8.3-fold (0.92 log units) below; measured number outside the range, above it.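

In this assay, replacing methyl with chloro on an aromatic carbon of the six-membered ring gives an 8.3-fold higher number from compound 2 to compound 3 (0.92 log units; beyond the scatter), the first sign that activity responds to a change at this place. Exchanging one heavy atom for another, with no change in the count of hydrogen-bond donors or acceptors, is enough to move the result beyond the usual scatter, and compound 3 is the weaker inhibitor of this pair. Nothing among the data shown accounts for this difference between 4-methylphenyl and 4-chlorophenyl.

The compounds shown leave open how a methoxy group, an amine or a plain hydrogen at this same place would compare with methyl and chloro, since a single step cannot show whether the trend extends to other groups. They also leave open whether the same exchange would have a similar effect alongside a different group on the carbon attached to the shared core, as compound 1 has the entry "not determined" (no result reported) and offers no number for such a comparison.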